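A few compounds are considered here, and "the series" means these few. Any claim that something is new, unique, unknown or untested is made for them only; others in the source may bear on it.

Compound 1, `CC(C)n1cc(-c2ccnc3[nH]c(C4CCN(CC(=O)N5CCCCC5)CC4)cc23)ccc1=O`, gives 8.1 L/kg in an ADME assay (Rattus norvegicus, strain Han-wistar) for pharmacokinetics, at a dose of 1.5 umol/kg by the intravenous route; on this read-out higher numbers stand for wider distribution into tissues and lower numbers for narrower distribution.
Compound 2, `CC(C)n1cc(-c2ccnc3[nH]c(C4CCN(CC(=O)N(C)C)CC4)cc23)cnc1=O`, gives 2.9 L/kg.
Compound 3, `COc1cc(F)ccc1-c1ccnc2[nH]c(C3CCN(C(C)=O)CC3)cc12`, gives 1.7 L/kg.

Compound 1 stands highest of the three. Compound 2 lies nearest to it, and that gap is already beyond the usual scatter of this assay; compound 3 lies furthest away, also beyond the scatter. No pair of these compounds differs in only one place, so no single step can be read from them.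

Compound 4, `CC(C)n1cc(-c2ccnc3[nH]c(C4CCN(Cc5cccs5)CC4)cc23)ccc1=O`, is not yet measured. It differs from compound 1 in one place: thiophen-2-yl in place of (piperidin-1-yl)carbonyl on a saturated chain carbon bound to an amine nitrogen in a ring. Cut one bond further out, the change reads ((piperidin-1-yl)carbonyl)methyl to (thiophen-2-yl)methyl, so the carbonyl of compound 1 is gone and an aromatic ring takes its place.

Going by the values given here, nothing among the measured compounds shows a change of this kind, so the expectation rests on compound 1 alone. The number for compound 4 is expected to move upward, by a step of a 1.7-fold higher number from compound 1 to compound 4 (0.24 log units; within the scatter), which would be beyond the scatter. For compound 4 the estimate is 14 L/kg, within a range from 7 L/kg to 28 L/kg.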

Compound 4, volume of distribution: 1.6 L/kg
The estimate for compound 4 lay 8.8-fold (0.94 log units) above the measured number, outside the stated range (below it).
By their numbers in this assay, from the lowest: compounds 4, 3 and 2 (each within the scatter of the next); then compound 1.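

In this assay, the group on a saturated chain carbon bound to an amine nitrogen in a ring proves able to shift the read-out on its own: thiophen-2-yl in place of (piperidin-1-yl)carbonyl gives a 5.1-fold lower number from compound 1 to compound 4 (0.70 log units; beyond the scatter). Going by these compounds alone, this is the first single-place comparison in the set, and its direction is downward. The change removes the carbonyl and replaces a six-membered non-aromatic ring with a five-membered aromatic one in the same step, and no measurement available here explains the drop.

Within the data shown here, the single step cannot separate the loss of the carbonyl from the change of ring. It also leaves open how a phenyl group, a morpholin-4-ylcarbonyl group or a carboxylic acid at this place would read.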